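Replacing an aromatic ring of compound 3 with bromo

The compounds below may be only part of what the source reports. "The series", "measured", "known", "first", "only" and "open" are said of these compounds alone.

Values so far in an ADME assay on HEK293 cells (Homo sapiens) for cytotoxicity, read by CellTiter-Glo and resazurin assay, with a stated time of 72 h (a lower number here means that less compound is needed, a higher number that more compound is needed for the effect), are:
- Compound 1 `CCOC(=O)CCCCCOc1cccc(CN(C(=O)c2ccc(-c3cccc(Br)c3)cc2)C(C)C)c1` gives > 26000 nM (a limit)
- Compound 2 `CCOC(=O)CCCCCOc1cccc(CN(C(=O)c2ccc(-c3cccc(Cl)c3)cc2)C(C)C)c1` gives > 18400 nM (a limit)
- Compound 3 `CCOC(=O)CCCCCOc1cccc(CN(C(=O)c2ccc(-c3cccc(CC(=O)O)c3)cc2)C(C)C)c1` gives > 26000 nM (a limit)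

In this assay compound 3 stands at > 26000 nM and that is a limit, not a number. So its exact place among the three compounds cannot be told.

Compound 4 `CCOC(=O)CCCCCOc1cccc(CN(C(=O)c2ccc(Br)cc2)C(C)C)c1` has not yet been measured. It carries bromo in place of 3-(carboxymethyl)phenyl on an aromatic carbon, para to a large group (bromo in place of 3-(carboxymethyl)phenyl on an aromatic carbon). The whole aromatic ring that varies across the first three compounds is therefore gone.

The measured steps bear on this only loosely, since each swaps a group on that ring. They are a step that the two limits leave unreadable from compound 1 to compound 2 and a step that the two limits leave unreadable from compound 1 to compound 3 and also a step that the two limits leave unreadable from compound 2 to compound 3 and none of them has a size that can be read. Bromo, chloro and carboxymethyl on that ring all ended in limits, and no compound goes against this among the three.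

With no readable size to build on, no step beyond the usual scatter is expected, and no direction can be favoured. The expected change is a step that the limit leaves unreadable from compound 3 to compound 4 and it is a rough expectation. For compound 4 the estimated value is 30000 nM with an expected range from 15000 nM to 60000 nM and a further limit is the likeliest report.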

Compound 4, half-maximal effective concentration: > 26000 nM
Compound 4 gave a limit, no number; the forecaster's own chance of this, stated with the estimate: 75%; the middle value is on the limit's open side.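

In this assay compound 4 gives > 26000 nM, which is a limit and not a number. Going by these compounds alone, compound 1, compound 2 and compound 3 also gave limits, and no step from any of them to compound 4 can be read. The compounds shown leave open how much of any of these four compounds is needed for the effect.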